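A ring replaces dimethylamino in compound 2

The source may hold more compounds than are shown below. What is called first, only, known or untested is meant among the compounds shown, and "the series" means these compounds.

Measured so far in a functional assay on PC-3 cells (Homo sapiens) for antiproliferative activity, read by MTT assay, with a stated time of 72 h; on this read-out higher numbers stand for weaker inhibition and lower numbers for stronger inhibition
- compound 1 `CCN(CC)CCn1cccc1/C=N/NC(=O)Nc1ccc(Oc2ccnc3[nH]ccc23)cc1` gives 1370 nM
- compound 2 `CN(C)CCCn1cccc1/C=N/NC(=O)Nc1ccc(Oc2ccnc3[nH]ccc23)cc1` gives 5150 nM

Compound 2 holds the higher of the two numbers and so shows the weaker inhibition. Compound 3 `CN1CCN(CCCn2cccc2/C=N/NC(=O)Nc2ccc(Oc3ccnc4[nH]ccc34)cc2)CC1` awaits measurement and carries 4-methylpiperazin-1-yl in place of dimethylamino, on a saturated chain carbon, three bonds along the chain from an aromatic nitrogen 4-methylpiperazin-1-yl in place of dimethylamino on a saturated chain carbon, three bonds along the chain from an aromatic nitrogen in the same chain. Within the data shown here, the only measured step is a 3.8-fold higher number from compound 1 to compound 2 (0.58 log units; beyond the scatter) and it swaps other groups, so it suggests a modest size but no firm direction. The estimated step is a 1.5-fold lower number from compound 2 to compound 3 (0.17 log units; within the scatter) and its direction remains uncertain. Compound 3 is estimated at 3500 nM with 1200 nM to 10000 nM as the expected range.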

Compound 3, half-maximal inhibitory concentration: 3740 nM
Estimate against measurement, compound 3: 1.1-fold (0.03 log units) below; the measured number falls inside the stated range.
By their numbers in this assay, from the lowest: compound 1; then compounds 3 and 2 (each within the scatter of the next).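

In this assay, replacing dimethylamino with the larger ring 4-methylpiperazin-1-yl gives a 1.4-fold lower number from compound 2 to compound 3 (0.14 log units; within the scatter) and so leaves the number at this position within the scatter. The ring therefore does not bring the propyl series level with the diethylamino compound, as a 2.7-fold higher number from compound 1 to compound 3 (0.44 log units; beyond the scatter) shows. Nothing available here explains these numbers.

The compounds shown leave open whether the ring's second nitrogen matters, which a morpholine or piperidine on the same propyl chain would test. They also leave chain length unseparated from the amine, which 2-(4-methylpiperazin-1-yl)ethyl on the same core would address.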